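Benzyl on the Aromatic Amine, Tested a Second Time

The compounds below may be only part of what the source reports. "The series", "measured", "known", "first", "only" and "open" are said of these compounds alone.

Compound 1 `CCNS(=O)(=O)c1ccc(NC2CC3CCC2C3)c(N)c1` and compound 2 `CNS(=O)(=O)c1ccc(NC2CCCCC2)c(N)c1` are built on two different cores; the difference between the two cores is not broken down here. Within the data shown here, in a functional assay (IMR-32 cells, Homo sapiens) for inhibition, read by fluorescence, with stated times of 1 h and 13 h (a lower number here means a stronger inhibitor, a higher number a weaker inhibitor), compound 1 gives 28 nM, while compound 2 gives 76 nM, the highest number of the three measured so far. Compound 3 `CCNS(=O)(=O)c1ccc(NC2CC3CCC2C3)c(NCc2ccccc2)c1` is compound 1 with one change, (benzyl in place of hydrogen on a nitrogen on an aromatic ring), and in this assay compound 3 gives 3 nM, a step of a 9.3-fold lower number from compound 1 to compound 3 (0.97 log units; beyond the scatter). Compound 4 `CNS(=O)(=O)c1ccc(NC2CCCCC2)c(NCc2ccccc2)c1` makes the same change on the core of compound 2, (benzyl in place of hydrogen on a nitrogen on an aromatic ring), at a place described in identical words. Compound 4 is therefore expected to fall to about 10 nM in this assay, with a likely range from 3 nM to 30 nM. Among the measured compounds shown here, the expected step of a 7.6-fold lower number from compound 2 to compound 4 (0.88 log units; beyond the scatter) is taken somewhat more cautiously than the single earlier step of a 9.3-fold lower number from compound 1 to compound 3 (0.97 log units; beyond the scatter), since only one example of the change is known.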

Compound 4, half-maximal inhibitory concentration: 3.7 nM
Estimate against measurement, compound 4: 2.7-fold (0.43 log units) above; the measured number falls inside the stated range.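

In this assay, benzyl in place of hydrogen on a nitrogen on an aromatic ring gives a 21-fold lower number from compound 2 to compound 4 (1.31 log units; beyond the scatter) and so repeats on a second core what it did on the first, the two steps not differing beyond the scatter: the same change on two cores in this assay, a 9.3-fold lower number (0.97 log units; beyond the scatter) from compound 1 to compound 3 and a 21-fold lower number (1.31 log units; beyond the scatter) from compound 2 to compound 4, 2.2-fold (0.34 log units) apart, within the scatter of two such steps. The change thus carried from the core of compound 1 to the core of compound 2 with little loss in the size of the step. Two cores and a single group are all this rests on, however, so it does not show that the step would hold on any further core, nor why it is this large.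

The compounds shown leave open whether a methyl or a longer chain such as phenethyl on the same nitrogen would give a like step. They also leave open whether a pyridylmethyl group would do so in place of benzyl.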